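Swapping a Cyclopropyl for Methoxyphenyl on the Ring Amide

A few compounds are considered here, and "the series" means these few. Any claim that something is new, unique, unknown or untested is made for them only; others in the source may bear on it.

Three compounds have already been measured in a functional assay on HepG2 cells (Homo sapiens) for antiproliferative activity, read by MTT assay, with a stated time of 72 h; on this read-out higher numbers stand for weaker inhibition and lower numbers for stronger inhibition:

Compound 1, `COc1ncc(-c2ccc3c(c2)N(C2CC2)C(=O)CO3)cc1NS(=O)(=O)c1ccc(F)cc1`, gives 14400 nM.
Compound 3, `COc1ccc(N2C(=O)COc3ccc(-c4cnc(OC)c(NS(=O)(=O)c5ccc(F)cc5)c4)cc32)cc1`, gives 13100 nM.
Compound 2, `O=C1COc2ccc(-c3cccc(NS(=O)(=O)c4ccc(F)cc4)c3)cc2N1C1CC1`, gives only a limit of this assay, > 40000 nM.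

Compound 1 and compound 3 share a core and differ in one place: 4-methoxyphenyl in place of cyclopropyl on an amide-type nitrogen in a ring. This change gave a 1.1-fold lower number from compound 1 to compound 3 (0.04 log units; within the scatter), so within this pair the larger group on the ring amide made no difference beyond the scatter. Compound 2 carries the cyclopropyl group of compound 1 on a different core; the difference between the two cores is not broken down here. For compound 2 the number sits at the limit of > 40000 nM in this assay, at which 1 of the 3 values shown sits.

Compound 4, `COc1ccc(N2C(=O)COc3ccc(-c4cccc(NS(=O)(=O)c5ccc(F)cc5)c4)cc32)cc1`, has not been measured. It stands to compound 2 as compound 3 stands to compound 1: 4-methoxyphenyl in place of cyclopropyl on an amide-type nitrogen in a ring. The place is described in the same words in both cases. Among the measured compounds shown here, the only measured example of this change, from compound 1 to compound 3, stayed within the scatter, and compound 2 is known only as a limit. The step from compound 2 to compound 4 is therefore expected to be small, a step that the limit leaves unreadable from compound 2 to compound 4, resting on a 1.1-fold lower number from compound 1 to compound 3 (0.04 log units; within the scatter). The estimate for compound 4 in this assay is 60000 nM, with a range from 30000 nM to 150000 nM, and most likely this assay would again report only a limit.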

Compound 4, half-maximal inhibitory concentration: 29800 nM
Compound 4: the middle estimate sits 2.0-fold (0.30 log units) above what was measured, and the stated range ends above it.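

In this assay compound 2 is known only through a limit of the assay, > 40000 nM, so any step that starts from it has a floor and not a full size. Putting 4-methoxyphenyl in place of cyclopropyl on the amide-type nitrogen gave an at least 1.3-fold lower number from compound 2 to compound 4 (0.12 log units; that floor lies within the scatter), and read beside the earlier pair, this shows that the swap did not push the number up on either core, though it does not show that the two cores respond to it alike: the same change on two cores in this assay, a 1.1-fold lower number (0.04 log units; within the scatter) from compound 1 to compound 3 and an at least 1.3-fold lower number (0.12 log units; that floor lies within the scatter) from compound 2 to compound 4; the limit leaves it open whether they differ Only two pairs carry this change, so nothing here reaches beyond these two cores, and the true size of the step on the core of compound 2 stays unknown, since one end of it rests on a limit: the limit of > 40000 nM in this assay, at which 1 of the 4 values shown sits.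

From the compounds shown here alone, only cyclopropyl and 4-methoxyphenyl appear on that ring nitrogen, so what a methyl, a plain phenyl or a longer chain ending in an amine would do there remains open. Going by these compounds, whether any group in that place could bring the number well below those of compound 3 and compound 4 also stays open.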